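The compounds below may be only part of what the source reports. "The series", "measured", "known", "first", "only" and "open" are said of these compounds alone.

Measured so far:
compound 1 `Cc1nc(-c2cnc3ccc(-c4ccc(N)cc4)cc3c2)no1` — > 2500 nM
compound 2 `CCCc1nc(-c2cnc3ccc(-c4ccc(N)cc4)cc3c2)no1` — > 800 nM

In a functional assay on RD cells (Homo sapiens) for inhibition, read by luminescence and ATP content, with a stated time of 72 h (on this read-out higher numbers stand for lower toxicity in this test and lower numbers for higher toxicity in this test), compound 1 gives > 2500 nM, which is a limit of the assay. Compound 2 gives > 800 nM, also a limit. The step that the two limits leave unreadable from compound 1 to compound 2 cannot be read, because both ends sit at limits the limit of > 2500 nM in this assay, at which 1 of the 2 values shown sits, and (the limit of > 800 nM in this assay, at which 1 of the 2 values shown sits). Compound 3 `COc1ccc(-c2ccc3ncc(-c4noc(C)n4)cc3c2)cc1` differs from compound 1 by methoxy in place of amino on an aromatic carbon. Going by the values given here, no measured step covers this change, and the single measured step is unreadable, so no direction beyond the scatter is expected. Compound 3 is estimated at 2500 nM, between 800 nM and 8000 nM. That estimate means an expected step of a number no higher from compound 1 to compound 3 (the limit leaves the size open).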

Compound 3, half-maximal cytotoxic concentration: > 66700 nM
Compound 3 gave a limit, no number; the forecaster's own chance of this, stated with the estimate: 60%; at least 26-fold (1.42 log units) between middle value and limit.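

Going by these compounds alone, compound 1 and compound 3 both sit at limits in this assay, so no step between them can be read. From the compounds shown here alone, whether methoxy in place of amino on an aromatic carbon shifts the half-maximal cytotoxic concentration remains open.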